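Will a 4-hydroxyphenyl group move a flat series?

A few compounds are considered here, and "the series" means these few. Any claim that something is new, unique, unknown or untested is made for them only; others in the source may bear on it.

Of the compounds shown here, three that share one core have so far been tested in a functional assay on A549 cells (Homo sapiens) for cytotoxicity, read by MTT assay, with a stated time of 72 h (on this read-out higher numbers stand for weaker inhibition and lower numbers for stronger inhibition), and their numbers sit almost on top of one another. Compound 1 (`COc1cc2ncnc(Nc3ccc(F)c(Cl)c3)c2cc1NC(=O)N/N=C/c1ccc(C#N)cc1`) gives 32200 nM in that test, compound 2 (`COc1cc2ncnc(Nc3ccc(F)c(Cl)c3)c2cc1NC(=O)N/N=C/c1ccc(OC)c(OC)c1OC`) gives 32800 nM and compound 3 (`COc1cc2ncnc(Nc3ccc(F)c(Cl)c3)c2cc1NC(=O)N/N=C/c1cc(OC)c(OC)c(OC)c1`) gives 32100 nM as its reading. Compound 3 is therefore level with the other two, with no real separation from either.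

Compound 4 (`COc1cc2ncnc(Nc3ccc(F)c(Cl)c3)c2cc1NC(=O)N/N=C/c1ccc(O)cc1`) has not yet been measured. It carries 4-hydroxyphenyl in place of 3,4,5-trimethoxyphenyl on a carbon with a double bond to nitrogen and the core stays the same.

The most relevant evidence comes from earlier swaps at this same place. They gave a 1.0-fold higher number from compound 1 to compound 2 (0.01 log units; within the scatter) and a 1.0-fold lower number from compound 1 to compound 3 (0.00 log units; within the scatter) and also a 1.0-fold lower number from compound 2 to compound 3 (0.01 log units; within the scatter) as their sizes, and all three lie within the scatter. Going by the values given here, no tested compound has a 4-hydroxyphenyl group, so this evidence is indirect and the range must stay wide.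

The step expected in this assay is a 1.0-fold lower number from compound 3 to compound 4 (0.02 log units; within the scatter) and nothing beyond the scatter is expected. For compound 4 the estimated value is 31000 nM with an expected range from 14000 nM to 60000 nM in this test.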

Compound 4, half-maximal inhibitory concentration: 7610 nM
The estimate for compound 4 lay 4.1-fold (0.61 log units) above the measured number; the measured number lies below the stated range.
By their numbers in this assay, from the lowest: compound 4; then compounds 3, 1 and 2 (each within the scatter of the next).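

In this assay the place on a carbon with a double bond to nitrogen now proves able to move the read-out: 4-hydroxyphenyl gives a 4.2-fold lower number from compound 3 to compound 4 (0.63 log units; beyond the scatter) and a 4.3-fold lower number from compound 2 to compound 4 (0.63 log units; beyond the scatter) and also a 4.2-fold lower number from compound 1 to compound 4 (0.63 log units; beyond the scatter) with all three steps beyond the usual scatter, whereas the earlier swaps there stayed within it. Going by these compounds alone, compound 1 has no methoxy groups on this ring and still sits level with compound 2 and compound 3, so losing the methoxy groups is not enough on its own to produce the shift, and the single swap of cyano for hydroxy is what separates compound 4 from compound 1. Nothing available here explains why the hydroxy group has this effect.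

On these data alone, whether the hydrogen-bond donor of the hydroxy group matters remains open, and 4-methoxyphenyl, which caps that oxygen, or 4-aminophenyl, which replaces it with nitrogen, would test this directly. As far as these compounds go, it is also open whether a larger group carrying a carboxylic acid would extend the shift or lose it.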